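Cytotoxicity of a bromo for trifluoromethyl swap

The source may report more compounds than this note shows. Statements on the series, on what has been measured and on what is new or still open speak of the compounds shown alone.

Compound 1 `COc1ccc(CN2C(=O)/C(=C/c3cc(C)n(-c4ccc(O)c(C(=O)O)c4)c3C)SC2=S)cc1` gives 75300 nM; compound 2 `Cc1cc(/C=C2\SC(=S)N(Cc3ccc(C(=O)O)cc3)C2=O)c(C)n1-c1ccc(O)c(C(=O)O)c1` gives 105000 nM; compound 3 `Cc1cc(/C=C2\SC(=S)N(Cc3cccc(C(F)(F)F)c3)C2=O)c(C)n1-c1ccc(O)c(C(=O)O)c1` gives 26300 nM.

In an ADME assay on MT2 cells (Homo sapiens) for cytotoxicity, read by XTT assay, with a stated time of 4 days (on this read-out higher numbers stand for lower toxicity in this test and lower numbers for higher toxicity in this test), compound 3 stands lowest of the three numbers, so it shows the highest toxicity measured here. Compound 4 `Cc1cc(/C=C2\SC(=S)N(Cc3cccc(Br)c3)C2=O)c(C)n1-c1ccc(O)c(C(=O)O)c1` differs from compound 3 in one place: bromo in place of trifluoromethyl on an aromatic carbon. For the measured compounds named here, none of the measured steps touches this group; a 2.9-fold lower number from compound 1 to compound 3 (0.46 log units; beyond the scatter) and a 4.0-fold lower number from compound 2 to compound 3 (0.60 log units; beyond the scatter) concern which ring sits on the benzyl carbon, and a 1.4-fold higher number from compound 1 to compound 2 (0.14 log units; within the scatter) concerns a remote aromatic carbon. These steps give no guide in direction for the bromo change, so for compound 4 a step within the scatter of compound 3 is expected, a 1.1-fold higher number from compound 3 to compound 4 (0.06 log units; within the scatter). Compound 4 is estimated at 30000 nM, within a range from 12000 nM to 75000 nM.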

Compound 4, half-maximal cytotoxic concentration: 48200 nM
Compound 4: middle estimate off by 1.6-fold (0.21 log units), on the low side; low and high end bracket the measured number.
By their numbers in this assay, from the lowest: compounds 3, 4, 1 and 2 (each within the scatter of the next, the first and the last beyond it).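

In this assay, changing trifluoromethyl to bromo gives a 1.8-fold higher number from compound 3 to compound 4 (0.26 log units; within the scatter) and so leaves no change that can be told from the scatter, even though one bromine atom replaces four heavy atoms. Compared with the 4-methoxyphenyl group, 3-bromophenyl gives a 1.6-fold lower number from compound 1 to compound 4 (0.19 log units; within the scatter) and stays within the scatter, whereas compared with 4-carboxyphenyl it gives a 2.2-fold lower number from compound 2 to compound 4 (0.34 log units; beyond the scatter) and goes beyond it. No measurement shown here explains these numbers. Going by these compounds, whether an amine or a carboxylic acid at this same place on the ring would give a similar number remains open.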